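Halogen for nitro on the chalcone aryl ring

A few compounds are considered here, and "the series" means these few. Any claim that something is new, unique, unknown or untested is made for them only; others in the source may bear on it.

Measured so far:
- compound 1, `O=C(COc1ccc(C(=O)/C=C/c2ccccc2Cl)cc1)N[C@H]1CCOC1=O`, in a functional assay on PC-3 cells (Homo sapiens) for antiproliferative activity, read by MTT assay, with a stated time of 72 h (a higher number here means a weaker inhibitor, a lower number a stronger inhibitor), gives 4610 nM
- compound 2, `O=C(COc1ccc(C(=O)/C=C/c2ccc(F)cc2)cc1)N[C@H]1CCOC1=O`, in this assay gives 15600 nM
- compound 3, `O=C(COc1ccc(C(=O)/C=C/c2cccc([N+](=O)[O-])c2)cc1)N[C@H]1CCOC1=O`, in this assay gives 56300 nM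

Compound 3 stands with the highest number of the three, separated from compound 2 by a 3.6-fold higher number from compound 2 to compound 3 (0.56 log units; beyond the scatter) and from compound 1 by a 12-fold higher number from compound 1 to compound 3 (1.09 log units; beyond the scatter). Compound 4, `O=C(COc1ccc(C(=O)/C=C/c2ccc(Br)cc2)cc1)N[C@H]1CCOC1=O`, differs from compound 3 in one place: 4-bromophenyl in place of 3-nitrophenyl on a double-bonded chain carbon bound to a double-bonded chain carbon. The step that bears most directly on this is a 3.6-fold higher number from compound 2 to compound 3 (0.56 log units; beyond the scatter), where a halogen on the aryl ring gave a modestly lower number than the nitro group; a 3.4-fold higher number from compound 1 to compound 2 (0.53 log units; beyond the scatter) shows the halogen ring itself can move the number further. A 4-bromophenyl in place of 3-nitrophenyl is therefore expected to move compound 4 toward the range of compound 2, an estimated 4.7-fold lower number from compound 3 to compound 4 (0.67 log units; beyond the scatter). Compound 4 is estimated at 12000 nM in this assay, with a range from 4000 nM to 32000 nM.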

Compound 4, half-maximal inhibitory concentration: > 64000 nM
Compound 4: a limit, no number; the forecaster's own chance of this, stated with the estimate: 5%; middle value at least 5.3-fold (0.72 log units) from the limit.
By their numbers in this assay, from the lowest: compound 1; then compound 2; then compound 3. At a limit, above all of these: compound 4.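

In this assay compound 4 stands at a limit of the assay, not a number: the limit of > 64000 nM in this assay, at which 1 of the 4 values shown sits. Against the 3-nitrophenyl the result gives only a floor, an at least 1.1-fold higher number from compound 3 to compound 4 (0.05 log units; that floor lies within the scatter), yet bromo in place of fluoro on an aromatic carbon gives an at least 4.1-fold higher number from compound 2 to compound 4 (0.61 log units; beyond the scatter), and the change from 2-chlorophenyl gives an at least 13-fold higher number from compound 1 to compound 4 (1.14 log units; beyond the scatter). At this position, then, a halogen on the aryl ring does not by itself give a lower number than the nitro group, and the identity of the halogen matters.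

On these data alone, how far compound 4 lies past its limit stays open, as does where a methoxy group or an amine on this ring would fall.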